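The source may report more compounds than this note shows. Statements on the series, on what has been measured and on what is new or still open speak of the compounds shown alone.

Three compounds share one core. Compound 1 `CCOC(=O)Nc1sc(-c2ccc(Cl)cc2)c(-c2ccc(Cl)cc2)c1C(=O)NC1CC1` gives 39800 nM in a functional assay on A549 cells (Homo sapiens) for inhibition, read by sulforhodamine B assay, with a stated time of 72 h; on this read-out higher numbers stand for weaker inhibition and lower numbers for stronger inhibition. Compound 2 `Nc1sc(-c2ccc(Cl)cc2)c(-c2ccc(Cl)cc2)c1C(=O)N1CCNCC1` gives 1020 nM, and compound 3 `Nc1sc(-c2ccc(Cl)cc2)c(-c2ccc(Cl)cc2)c1C(=O)NC1CCCC1` gives 6790 nM, the second highest of the three numbers: compound 1 sits further up, and the other gap is a 6.7-fold higher number from compound 2 to compound 3 (0.82 log units; beyond the scatter). Compound 4 `CC(C)CNC(=O)c1c(N)sc(-c2ccc(Cl)cc2)c1-c1ccc(Cl)cc1` differs from compound 3 by isobutyl in place of cyclopentyl on an amide-type nitrogen. Going by the values given here, the only measured step alters the group on the carbonyl carbon, not the alkyl group on the amide-type nitrogen, so no measured step speaks to this change. No shift beyond the scatter is therefore expected, and the estimate for compound 4 is 7000 nM, with a range from 3000 nM to 16000 nM. That estimate corresponds to an expected 1.0-fold higher number from compound 3 to compound 4 (0.01 log units; within the scatter).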

Compound 4, half-maximal inhibitory concentration: 21000 nM
Compound 4: the middle estimate sits 3.0-fold (0.48 log units) below what was measured, and the stated range ends below it.
By their numbers in this assay, from the lowest: compound 2; then compound 3; then compounds 4 and 1 (each within the scatter of the next).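

In this assay, the group on the amide-type nitrogen clearly affects the number: isobutyl in place of cyclopentyl gives a 3.1-fold higher number from compound 3 to compound 4 (0.49 log units; beyond the scatter), even though neither group carries a hydrogen-bond donor, acceptor or net charge. Measured against piperazin-1-yl on the carbonyl carbon, isobutylamino gives a 21-fold higher number from compound 2 to compound 4 (1.31 log units; beyond the scatter), a larger step than the one to cyclopentylamino. No measurement here explains why the open chain and the ring differ. On these data alone, it remains open whether a cyclohexyl ring, a longer straight chain or a chain ending in an amine on this nitrogen would give lower numbers.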